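This account rests on a few compounds, and the source may have more. Where it says the series, first, only, none or still open, it means among the compounds named here.

Measured in a functional assay on MCF7 cells (Homo sapiens) for inhibition, read by CCK-8 assay, with a stated time of 48 h; a higher number here means a weaker inhibitor of growth, a lower number a stronger inhibitor of growth:
- compound 1 `Cc1ccc(Nc2ncc(Cl)c(Nc3ccccc3C)n2)cc1`: > 100000 nM, a limit of the assay and not a number
- compound 2 `CCN1CCN(c2ccc(Nc3ncc(Cl)c(Nc4ccccc4C)n3)nc2)CC1`: > 100000 nM, a limit of the assay and not a number
- compound 3 `CN1CCN(c2ccc(Nc3ncc(Cl)c(Nc4ccccc4)n3)nc2)CC1`: 51800 nM

Compound 3, at 51800 nM, is the only one of the three with an actual number. The rest of the picture is the limit of > 100000 nM in this assay, at which 2 of the 3 values shown sit, and no single structural change between measured compounds can be sized from these results.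

Compound 4 `Cc1ccc(CNc2nc(Nc3ccc(N4CCN(C)CC4)cn3)ncc2Cl)cc1` is still unmeasured. It differs from compound 3 in one place: 4-methylbenzyl in place of phenyl on a nitrogen on an aromatic ring. Here 4-methylbenzyl stands in place of phenyl on a nitrogen on an aromatic ring, so anilino becomes (4-methylbenzyl)amino.

Among the measured compounds shown here, with no measured step to lean on, the only firm anchor is compound 3 at 51800 nM. A modest change in this assay is expected, leaning slightly towards stronger growth inhibition, though a result at the limit would be no surprise. The expected move is a 1.7-fold lower number from compound 3 to compound 4 (0.24 log units; within the scatter). For compound 4 the estimated value is 30000 nM, with an expected range of 5000 nM to 100000 nM.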

Compound 4, concentration for 50% growth inhibition: 38100 nM
Estimate against measurement, compound 4: 1.3-fold (0.10 log units) below, and the stated range covers the measured number.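

In this assay, the change from anilino to (4-methylbenzyl)amino gives a 1.4-fold lower number from compound 3 to compound 4 (0.13 log units; within the scatter). Among the compounds shown here, this is the first step in the set that can be sized, and it shows that this nitrogen can carry the 4-methylbenzyl group in place of phenyl with no change that stands clear of the usual scatter. Compound 4 also gives a real number, unlike the compounds that sit at the limit of the assay: the limit of > 100000 nM in this assay, at which 2 of the 4 values shown sit.

Going by these compounds, whether a plain benzyl group, a longer phenethyl chain or a saturated cyclohexyl ring on this nitrogen would move the number beyond the scatter remains open. Also open, on these data alone, is whether the methyl on the ring and the added carbon link each have an effect of their own, since here they arrive together in a single change.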